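This account rests on a few compounds, and the source may have more. Where it says the series, first, only, none or still open, it means among the compounds named here.

Measured in a functional assay on MCF7 cells (Homo sapiens) for cytotoxicity, read by sulforhodamine B assay, with a stated time of 72 h; a lower number here means a stronger inhibitor, a higher number a weaker inhibitor:
- compound 1 `Cc1ccccc1NC(=O)Nc1ccc(Nc2ncnc3c2cnn3-c2ccc(Cl)cc2)cc1`: 3150 nM
- compound 2 `O=c1sc2cc(Nc3ncnc4c3cnn4-c3ccccc3)ccc2n1Cc1cccc(Br)c1`: 46100 nM
- compound 3 `O=c1sc2cc(Nc3ncnc4c3cnn4-c3ccccc3)ccc2n1Cc1ccc(Cl)cc1Cl`: 44000 nM

Compound 1 has the lowest number of the three, and its gap to each of the other two lies beyond the scatter. Compound 4 `Clc1ccc(COc2ccc(Nc3ncnc4c3cnn4-c3ccc(Cl)cc3)cc2)cc1` keeps the core of compound 1 but carries (4-chlorobenzyl)oxy in place of ((2-methylphenyl)carbamoyl)amino on an aromatic carbon, para to a large group ((4-chlorobenzyl)oxy in place of ((2-methylphenyl)carbamoyl)amino on an aromatic carbon).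

Within the data shown here, no measured step covers this exchange. The only one available is a 1.0-fold lower number from compound 2 to compound 3 (0.02 log units; within the scatter), which lies within the scatter. It swaps 3-bromophenyl for 2,4-dichlorophenyl and leaves the rest of the molecule untouched, so it gives no size for the change at hand. Among the measured compounds shown here, it shows only that this one swap left the number in this assay unmoved.

The better guide is the values themselves. Neither compound 2 at 46100 nM nor compound 3 at 44000 nM carries ((2-methylphenyl)carbamoyl)amino, and both stand well above compound 1 at 3150 nM. These compounds also differ from compound 1 elsewhere, so the comparison is loose, and a moderate rise toward a weaker inhibitor is expected rather than a full jump to their level.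

The expected change is a 4.4-fold higher number from compound 1 to compound 4 (0.65 log units; beyond the scatter). For compound 4 the estimated value is 14000 nM, with an expected range from 3000 nM to 60000 nM.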

Compound 4, half-maximal inhibitory concentration: > 100000 nM
Compound 4 ended at the assay's limit (the forecaster's own chance of this, stated with the estimate: 10%); middle value at least 7.1-fold (0.85 log units) away from the limit.
By their numbers in this assay, from the lowest: compound 1; then compounds 3 and 2 (each within the scatter of the next). At a limit, above all of these: compound 4.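

In this assay, this position, an aromatic carbon para to a large group, proves far from indifferent to what it carries: putting (4-chlorobenzyl)oxy in place of ((2-methylphenyl)carbamoyl)amino on the core of compound 1 gives an at least 31-fold higher number from compound 1 to compound 4 (1.50 log units; beyond the scatter) and counts as a large step. Among these compounds, the only earlier step, a 1.0-fold lower number from compound 2 to compound 3 (0.02 log units; within the scatter), concerned a different place and so said nothing about this carbon. Compound 4 stands at a limit of the assay and not at a measured number: the limit of > 100000 nM in this assay, at which 1 of the 4 values shown sits.

This single exchange changes several things at once: the group that leaves carries hydrogen-bond donors and the 2-methylphenyl ring, while the group that enters carries no donors and brings a chlorine, and the compounds shown do not separate these changes. As far as these compounds go, whether an amine, a plain acetamide or a longer chain on this carbon would stay close to compound 1 remains open, as does how far beyond its limit compound 4 actually lies.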